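The compounds below may be only part of what the source reports. "The series", "measured", "known", "first", "only" and "open" are said of these compounds alone.

Compound 1 `COc1ccc(N2NC3=CC[C@@H](OC)O[C@@]3(c3ccccc3)CC2=O)cc1` and compound 2 `CO[C@@H]1CC=C2NN(c3cncnc3)C(=O)C[C@]2(C)O1` share one core. In a functional assay on SK-N-SH cells (Homo sapiens) for inhibition, read by sulforhodamine B assay, with a stated time of 48 h (a higher number here means a weaker inhibitor, a lower number a stronger inhibitor), compound 1 gives 10400 nM, and in the same assay compound 2 gives 16600 nM. Of these two numbers compound 2 sits at the top, but its gap to compound 1 lies within the usual scatter, so the two cannot be told apart. Compound 3 `CO[C@@H]1CC=C2NN(c3cncnc3)C(=O)C[C@]2(c2ccccc2)O1` has not yet been measured in this assay. It differs from compound 2 in one place, (phenyl in place of methyl on a saturated ring carbon), that is, phenyl in place of methyl on a saturated ring carbon. Going by the values given here, no measured pair isolates this change; compound 1, which also carries phenyl on that saturated ring carbon but a different group on the ring nitrogen, is within the scatter of compound 2. Compound 3 is therefore expected to show no step beyond the scatter, a 1.4-fold lower number from compound 2 to compound 3 (0.14 log units; within the scatter). For compound 3 the estimate in this assay is 12000 nM, between 5000 nM and 30000 nM.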

Compound 3, half-maximal inhibitory concentration: 8200 nM
Beside the measured number, compound 3's estimate is 1.5-fold (0.17 log units) above it; measured number inside the range.
By their numbers in this assay, from the lowest: compounds 3, 1 and 2 (each within the scatter of the next, the first and the last beyond it).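

The saturated ring carbon next to the ring oxygen now has a pair of its own. With pyrimidin-5-yl held on the ring nitrogen, phenyl in place of methyl gives, in this assay, a 2.0-fold lower number from compound 2 to compound 3 (0.31 log units; beyond the scatter), a modest step, so this position does respond to the change. With phenyl held on that carbon, pyrimidin-5-yl in place of 4-methoxyphenyl on the amide-type nitrogen gives a 1.3-fold lower number from compound 1 to compound 3 (0.10 log units; within the scatter), so those two groups cannot be told apart here, and nothing available accounts for either step.

Going by these compounds, it remains open whether an ethyl group, or a phenyl carrying a fluorine or a carboxylic acid, would move the number further at this carbon. On these data alone, it is also open whether the step from methyl to phenyl recurs with 4-methoxyphenyl on the ring nitrogen.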